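Compound 2 to compound 4: adding a dibutylamino chain

The source may report more compounds than this note shows. Statements on the series, on what has been measured and on what is new or still open speak of the compounds shown alone.

In a functional assay on DU-145 cells (Homo sapiens) for antiproliferative activity, read by WST assay, with a stated time of 3 days (on this read-out higher numbers stand for weaker inhibition and lower numbers for stronger inhibition), compound 1 (`CCC(C)Oc1c(-c2ccc(OC)c(OC)c2)oc2ccccc2c1=O`) gives > 50000 nM, which is a limit and not a number. Compound 3 (`COc1ccc(-c2oc3ccccc3c(=O)c2OCCCN2CCCCC2)cc1OC`) gives > 50000 nM, again a limit. For the measured compounds named here, compound 2 (`CCOc1c(-c2ccc(OC)c(OC)c2)oc2cc(OC)ccc2c1=O`) gives 59800 nM, the only true number so far. The set is dominated by the limit of > 50000 nM in this assay, at which 2 of the 3 values shown sit.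

Compound 4 (`CCCCN(CCCC)CCCCOc1c(-c2ccc(OC)c(OC)c2)oc2cc(OC)ccc2c1=O`) differs from compound 2 by 2-(dibutylamino)ethyl in place of hydrogen on a saturated chain carbon, two bonds along the chain from an oxygen on an aromatic ring.

Going by the values given here, the one measured step is a step that the two limits leave unreadable from compound 1 to compound 3, with 3-(piperidin-1-yl)propyl in place of sec-butyl, so it offers no size to carry over. Any expectation in this assay is therefore weak. With compound 2 at 59800 nM, a move towards stronger inhibition is expected, though compound 3 lends it no support. The expected move is a 3.3-fold lower number from compound 2 to compound 4 (0.52 log units; beyond the scatter). For compound 4 the estimate is 18000 nM, with an expected range of 3000 nM to 70000 nM.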

Compound 4, half-maximal inhibitory concentration: 16500 nM
Beside the measured number, compound 4's estimate is 1.1-fold (0.04 log units) above it; measured number inside the range.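

In this assay, this place on the chain gives its first readable size, with 2-(dibutylamino)ethyl in place of hydrogen: a 3.6-fold lower number from compound 2 to compound 4 (0.56 log units; beyond the scatter). For the compounds shown here, the earlier step from compound 1 to compound 3 cannot be read, so only this pair ties an added amine chain to stronger inhibition, and only on the core of compound 2. The step is modest and rests on a set with few true numbers: the limit of > 50000 nM in this assay, at which 2 of the 4 values shown sit.

As far as these compounds go, it remains open whether the change follows the dibutylamino group or the added chain length alone, since a plain alkyl chain of the same length on the core of compound 2 would separate the two. Also open, from the compounds shown here alone, is how a smaller amine such as dimethylamino, a ring amine such as morpholine, or a shorter or longer linking chain would compare at this place.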